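Methyl capping of a ring hydroxyl in a flavone series

The source may hold more compounds than are shown below. What is called first, only, known or untested is meant among the compounds shown, and "the series" means these compounds.

Measured so far:
compound 1 `COc1cc(-c2cc(=O)c3cc(O)ccc3o2)cc(OC)c1OC` — 5.87 ug/mL
compound 2 `COc1cc(-c2cc(=O)c3ccc(O)cc3o2)cc(OC)c1OC` — > 25 ug/mL
compound 3 `COc1ccc2oc(-c3cc(OC)c(OC)c(OC)c3)cc(=O)c2c1` — > 25 ug/mL

In a functional assay on SK-MEL cells (Homo sapiens) for cytotoxicity, read by MTT assay, with a stated time of 6 days (on this read-out lower numbers stand for an effect already at smaller amounts and higher numbers for an effect only at larger amounts of compound), compound 1 gives 5.87 ug/mL. Compound 2 gives > 25 ug/mL, which is a limit of the assay and not a number. Compound 3 gives > 25 ug/mL, likewise a limit. Compound 1 and compound 2 have the same atoms joined differently; the difference between the two cores is not broken down here.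

One change occurs twice among the compounds. From compound 1 to compound 3 it is methyl in place of hydrogen on an oxygen on an aromatic ring, and it gave an at least 4.2-fold higher number from compound 1 to compound 3 (0.62 log units; beyond the scatter), the step running up to the limit of > 25 ug/mL in this assay, at which 2 of the 3 values shown sit, and so being open at the top. The same change, (methyl in place of hydrogen on an oxygen on an aromatic ring), leads from compound 2 to the unmeasured compound 4 `COc1ccc2c(=O)cc(-c3cc(OC)c(OC)c(OC)c3)oc2c1`; the place lines read the same word for word.

The expectation for compound 4 rests on the parallel step an at least 4.2-fold higher number from compound 1 to compound 3 (0.62 log units; beyond the scatter) and on the fact that compound 2 already sits at the limit of > 25 ug/mL in this assay, at which 2 of the 3 values shown sit. The step from compound 2 to compound 4 is estimated as a step that the limit leaves unreadable from compound 2 to compound 4, at best nominal, with the result most likely again a limit. Compound 4 is estimated at 45 ug/mL, within 20 ug/mL to 120 ug/mL.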

Compound 4, concentration for half-maximal effect: > 25 ug/mL
Compound 4 ended at the assay's limit; the forecaster's own chance of this, stated with the estimate: 85%; the middle value is on the limit's open side.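

Compound 2 and compound 4 both give a limit and not a number in this assay, so no new step can be read between them: the limit of > 25 ug/mL in this assay, at which 3 of the 4 values shown sit.

From the compounds shown here alone, whether hydroxy to methoxy changes anything on the core of compound 2, as it does on the core of compound 1, remains open.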